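A few compounds are considered here, and "the series" means these few. Any claim that something is new, unique, unknown or untested is made for them only; others in the source may bear on it.

The study covers four compounds sharing a urea-hydrazone arrangement. Compound 1 `O=C(N/N=C/c1ccc(O)cc1)Nc1ccc(Oc2ccnc3[nH]ccc23)c(F)c1` gives 1950 nM in a functional assay on HepG2 cells (Homo sapiens) for antiproliferative activity, read by MTT assay, with a stated time of 72 h (on this read-out higher numbers stand for weaker inhibition and lower numbers for stronger inhibition), and compound 2 `O=C(N/N=C/c1ccc(O)c(Br)c1)Nc1ccc(Oc2ccnc3[nH]ccc23)c(F)c1` gives 1360 nM. The change between them, (bromo in place of hydrogen on an aromatic carbon), made a step of a 1.4-fold lower number from compound 1 to compound 2 (0.16 log units; within the scatter). Compound 3 `O=C(N/N=C/c1ccccc1)Nc1ccc(Oc2ccnc3[nH]ccc23)cc1` gives 750 nM in this assay; the difference between its core and the core of compound 1 is not broken down here. Compound 4 `O=C(N/N=C/c1ccc(Br)cc1)Nc1ccc(Oc2ccnc3[nH]ccc23)cc1` has not been measured. It differs from compound 3 by bromo in place of hydrogen on an aromatic carbon, the same kind of change as that from compound 1 to compound 2, though here the place is para to a large group rather than ortho to a hydroxy group and meta to a large group. In this assay compound 4 is expected to show a step of a 1.3-fold lower number from compound 3 to compound 4 (0.10 log units; within the scatter), an expectation resting on the earlier step of a 1.4-fold lower number from compound 1 to compound 2 (0.16 log units; within the scatter). Compound 4 is therefore estimated at 600 nM, between 250 nM and 1400 nM.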

Compound 4, half-maximal inhibitory concentration: 1000 nM
The estimate for compound 4 lay 1.7-fold (0.22 log units) below the measured number; measured number inside the range.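

In this assay, bromo in place of hydrogen on an aromatic carbon gives a 1.3-fold higher number from compound 3 to compound 4 (0.12 log units; within the scatter), and the two cores do not separate on this change: the same change on two cores in this assay, a 1.4-fold lower number (0.16 log units; within the scatter) from compound 1 to compound 2 and a 1.3-fold higher number (0.12 log units; within the scatter) from compound 3 to compound 4, 1.9-fold (0.28 log units) apart, within the scatter of two such steps. In this series, neither step nor the gap between them stands out from the scatter, so the change carries across these two cores without a detectable difference. This does not show that the step is truly the same on both cores, or that bromo has any real effect on either, and two small steps at different places on cores that differ elsewhere cannot settle that.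

Going by these compounds, it remains open whether chloro, a methoxy group or an amine on the same carbon would give a step beyond the scatter. Also open, on these data alone, is how 4-bromophenyl would read on the core of compound 1.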